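A few compounds are considered here, and "the series" means these few. Any claim that something is new, unique, unknown or untested is made for them only; others in the source may bear on it.

Compound 1 `COc1ccccc1C(=O)Nc1nnc(SCC(=O)Nc2ccc(Br)cn2)s1`: in a functional assay on A875 cells (Homo sapiens) for antiproliferative activity, read by MTT assay, with a stated time of 48 h (on this read-out higher numbers stand for weaker inhibition and lower numbers for stronger inhibition), compound 1 gives > 80000 nM, which is a limit of the assay.
Compound 2 `COc1ccccc1C(=O)Nc1nnc(SCC(=O)Nc2c(C)ccnc2Cl)s1`: in this assay compound 2 gives > 80000 nM, which is a limit of the assay.

Compound 2 therefore stands at the limit and nowhere else on the numbers shown, and the only other value shown sits at the same limit (the limit of > 80000 nM in this assay, at which 2 of the 2 values shown sit). Within the data shown here, the one measured step, a step that the two limits leave unreadable from compound 1 to compound 2, is left unreadable by the two limits. Compound 3 `Cc1ccnc(Cl)c1NC(=O)CSc1nnc(NC(=O)CCl)s1` differs from compound 2 by chloromethyl in place of 2-methoxyphenyl on a carbonyl carbon. No measured step touches this carbonyl carbon, so nothing shown bears on the change. The limits shown leave no basis for expecting a readable step from compound 2 to compound 3, and the expected step is a number no higher from compound 2 to compound 3 (the limit leaves the size open). Compound 3 is expected to give 80000 nM in this assay, with a range from 15000 nM to 300000 nM.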

Compound 3, half-maximal inhibitory concentration: 34700 nM
For compound 3 the middle estimate is 2.3-fold (0.36 log units) above the measured one; low and high end bracket the measured number.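

Among these compounds, on the carbonyl carbon, chloromethyl in place of 2-methoxyphenyl gives the first readable step in this assay, an at least 2.3-fold lower number from compound 2 to compound 3 (0.36 log units; beyond the scatter). Compound 1 and compound 2 both stay at a limit of the assay, so the step between them cannot be read: the limit of > 80000 nM in this assay, at which 2 of the 3 values shown sit. With 2-chloro-4-methylpyridin-3-yl on the amide-type nitrogen, a measurable number therefore does not depend on keeping the six-membered aromatic ring of 2-methoxyphenyl on this carbonyl carbon.

The compounds shown do not tell whether the step belongs to the chlorine of chloromethyl or to the loss of 2-methoxyphenyl, a distinction that a plain methyl or a longer chain such as chloroethyl on this carbonyl carbon could draw. They also leave open whether chloromethyl would give a readable number with 5-bromopyridin-2-yl on the amide-type nitrogen.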